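The compounds below may be only part of what the source reports. "The series", "measured", "known", "first", "only" and "open" are said of these compounds alone.

In a functional assay on DU-145 cells (Homo sapiens) for inhibition, read by trypan blue exclusion, with a stated time of 72 h (on this read-out lower numbers stand for stronger inhibition and higher numbers for weaker inhibition), compound 1 (`COc1ccc(Nc2ncc3cc(S(=O)(=O)c4ccc(Cl)cc4)c(=O)n(C)c3n2)cc1`) gives 30000 nM, while compound 2 (`Cn1c(=O)c(S(=O)(=O)c2ccc(Cl)cc2)cc2cnc(Nc3ccc4[nH]ccc4c3)nc21`) gives 250 nM, the lower of the two numbers. Compound 3 (`Cn1c(=O)c(S(=O)(=O)c2ccc(N)cc2F)cc2cnc(Nc3ccc4[nH]ccc4c3)nc21`) differs from compound 2 on a sulfonyl sulfur: 4-amino-2-fluorophenyl in place of 4-chlorophenyl on a sulfonyl sulfur. Going by the values given here, the only measured step, a 120-fold lower number from compound 1 to compound 2 (2.08 log units; beyond the scatter), was large but involved a change on a nitrogen on an aromatic ring, so it gives no direct measure of this sulfonyl change. With no such evidence, a 1.7-fold lower number from compound 2 to compound 3 (0.22 log units; within the scatter) is expected, a shift not beyond the scatter. For compound 3 the estimated value is 150 nM, with an expected range from 30 nM to 800 nM.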

Compound 3, half-maximal inhibitory concentration: 8000 nM
The estimate for compound 3 lay 53-fold (1.73 log units) below the measured number; the measured number lies above the stated range.
By their numbers in this assay, from the lowest: compound 2; then compound 3; then compound 1.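

In this assay, the group on the sulfonyl sulfur proves to matter: 4-amino-2-fluorophenyl in place of 4-chlorophenyl gives a 32-fold higher number from compound 2 to compound 3 (1.51 log units; beyond the scatter). Compound 3 keeps the 1H-indol-5-yl group on the nitrogen and still gives 8000 nM, so that group alone does not secure the low number of compound 2. No measurement shown here accounts for this step. Because the amino group and the fluorine enter together, the compounds shown leave open which of them carries the step. On these data alone, how a carboxylic acid on that phenyl ring would read also remains open.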